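This account rests on a few compounds, and the source may have more. Where it says the series, first, only, none or still open, it means among the compounds named here.

Of the compounds shown here, three sharing one core have been tested in a functional assay on SMMC-7721 cells (Homo sapiens) for antiproliferative activity, read by MTT assay, with a stated time of 48 h; a lower number here means a stronger inhibitor, a higher number a weaker inhibitor. Compound 1 `CC(=O)OC/C1=C/C[C@](C)(CCC=C(C)C)/C=C/[C@@H](OC(=O)C=C(C)C)[C@](C)(O)/C=C/C1=O`, with acetoxymethyl on a double-bonded ring carbon, gives 2950 nM. Compound 2 `CC(C)=CCC[C@]1(C)/C=C/[C@@H](OC(=O)C=C(C)C)[C@](C)(O)/C=C/C(=O)/C(C(=O)O)=C\C1`, with carboxy in that place, reads > 10000 nM, which is a limit of the assay and not a number. Compound 3 `CCN(CC)C/C1=C/C[C@](C)(CCC=C(C)C)/C=C/[C@@H](OC(=O)C=C(C)C)[C@](C)(O)/C=C/C1=O`, with (diethylamino)methyl there, gives 570 nM, the lowest number of the three.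

Compound 4 `CC(C)=CCC[C@]1(C)/C=C/[C@@H](OC(=O)C=C(C)C)[C@](C)(O)/C=C/C(=O)/C(CN(C(C)C)C(C)C)=C\C1` alters this same group: diisopropylamino in place of diethylamino on a saturated chain carbon bound to a double-bonded ring carbon.

Only the measured steps at this place bear on the change. The data show a 5.2-fold lower number from compound 1 to compound 3 (0.71 log units; beyond the scatter) and, larger still, an at least 17-fold lower number from compound 2 to compound 3 (1.24 log units; beyond the scatter), while the reverse comparison among the first two gives an at least 3.3-fold higher number from compound 1 to compound 2 (0.53 log units; beyond the scatter). All of these exchange one kind of group for a quite different kind, whereas compound 4 only swaps the ethyl-bearing amino group for its isopropyl-bearing relative. Going by the values given here, no measured step makes such a swap, so these sizes serve only as an upper guide. The expected outcome in this assay is no step beyond the scatter, estimated as a 1.2-fold higher number from compound 3 to compound 4 (0.09 log units; within the scatter). The starting point is compound 3 at 570 nM. The estimated value for compound 4 is 700 nM, with an expected range from 250 nM to 2000 nM.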

Compound 4, half-maximal inhibitory concentration: 340 nM
The estimate for compound 4 lay 2.1-fold (0.31 log units) above the measured number; the range from low to high includes it.
By their numbers in this assay, from the lowest: compounds 4 and 3 (each within the scatter of the next); then compound 1. At a limit, above all of these: compound 2.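

In this assay, diisopropylamino in place of diethylamino gives a 1.7-fold lower number from compound 3 to compound 4 (0.22 log units; within the scatter), so at this place, on a saturated chain carbon bound to a double-bonded ring carbon, the two amino groups cannot be told apart. The earlier compounds showed a lower number with diethylamino alone, and a second amine now shows the same direction, with an 8.7-fold lower number from compound 1 to compound 4 (0.94 log units; beyond the scatter) and an at least 29-fold lower number from compound 2 to compound 4 (1.46 log units; beyond the scatter); among the compounds shown, both amines read lower than the acetoxy and carboxy compounds, and none goes against this. Compound 2 stands at a limit of the assay and not at a number, so the step from it gives only a minimum size: the limit of > 10000 nM in this assay, at which 1 of the 4 values shown sits.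

What the compounds shown leave open is whether the result holds for amines of other shapes at this place, such as a ring amine like piperidine or morpholine, a primary amine, or an amine carried on a longer chain. Going by these compounds alone, only two amino groups can be compared here, and they lie within the scatter of each other, so they set no trend for how far the alkyl groups on the nitrogen can be changed.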